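Biaryl terminus swap on the shared core of compound 2

The compounds below may be only part of what the source reports. "The series", "measured", "known", "first", "only" and "open" are said of these compounds alone.

Of the compounds shown here, two carry numbers so far. In a functional assay for agonist activity at G protein-coupled receptor 88 (Homo sapiens), read by HTRF and cAMP accumulation (a lower number here means that less compound is needed, a higher number that more compound is needed for the effect), compound 1 `CC[C@H](C)[C@H](N)CN(C(=O)[C@@H]1C[C@H]1c1csc(C)n1)c1ccc(-c2ccccc2)cc1` gives 1500 nM. Compound 2 `CC(C)C[C@H](N)CN(C(=O)[C@@H]1C[C@H]1c1ccccc1)c1ccc(C2=CCCC2)cc1` gives 1200 nM in this assay and stands alongside compound 1, the gap between them within the scatter. Compound 3 `COc1cccc(-c2ccc(N(C[C@@H](N)CC(C)C)C(=O)[C@@H]3C[C@H]3c3ccccc3)cc2)c1` follows from compound 2 by 3-methoxyphenyl in place of cyclopent-1-en-1-yl on an aromatic carbon. Going by the values given here, no measured pair shows this change. A small step toward a lower number is expected, a 1.3-fold lower number from compound 2 to compound 3 (0.12 log units; within the scatter), one that may not clear the scatter. Compound 3 is estimated at 900 nM, between 300 nM and 2700 nM.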

Compound 3, half-maximal effective concentration: 1100 nM
For compound 3 the middle estimate is 1.2-fold (0.09 log units) below the measured one; low and high end bracket the measured number.
By their numbers in this assay, from the lowest: compounds 3, 2 and 1 (each within the scatter of the next).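

At this position, on an aromatic carbon para to a large group, 3-methoxyphenyl in place of cyclopent-1-en-1-yl amounts to a 1.1-fold lower number from compound 2 to compound 3 (0.04 log units; within the scatter) in this assay and so leaves the number unresolved from that of compound 2. The position thus takes a six-membered aromatic ring with one hydrogen-bond acceptor as well as a five-membered non-aromatic ring, with no change that can be read. No supporting data bear on why the step is this small here.

Still open, as far as these compounds go, is whether a carboxylic acid or an aminomethyl group on this terminal ring would move the number beyond the scatter.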